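A few compounds are considered here, and "the series" means these few. Any claim that something is new, unique, unknown or untested is made for them only; others in the source may bear on it.

Compound 1 `O=C(/C=C\c1ccc(Cl)cc1)N1N=C(c2ccncc2)OC1c1c[nH]c2ccccc12` gives, in an ADME assay on HeLa cells (Homo sapiens) for cytotoxicity, read by MTT assay, with a stated time of 72 h (on this read-out higher numbers stand for weaker inhibition of growth and lower numbers for stronger inhibition of growth), a result that is a limit: > 30 ug/mL.
Compound 2 `O=C(/C=C\c1cccc(Cl)c1Cl)N1N=C(c2ccncc2)OC1c1c[nH]c2ccccc12` gives, in this assay, a result that is also a limit: > 30 ug/mL.
Compound 3 `O=C(/C=C/c1c(Cl)cccc1Cl)N1N=C(c2ccncc2)OC1c1c[nH]c2ccccc12` gives, in this assay, a result that is again a limit: > 30 ug/mL.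

Compound 3 therefore stands at the limit of this assay, and there is no number for it, only the sign that growth inhibition was not reached in the tested range. The same holds for the two other compounds measured, as the limit of > 30 ug/mL in this assay, at which 3 of the 3 values shown sit, records.

Compound 4 `O=C(/C=C\c1ccc(Br)cc1)N1N=C(c2ccncc2)OC1c1c[nH]c2ccccc12` has not yet been measured. It differs from compound 3 in one place: 2-(4-bromophenyl)ethenyl in place of 2-(2,6-dichlorophenyl)ethenyl on a carbonyl carbon. The measured steps that bear on a change of the aryl substitution are a step that the two limits leave unreadable from compound 1 to compound 2, a step that the two limits leave unreadable from compound 1 to compound 3 and a step that the two limits leave unreadable from compound 2 to compound 3; all three are unreadable in size, since both ends of each step sit at the limit.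

Nothing among these three steps suggests that moving a halogen around the phenyl ring, or exchanging one halogen for another, brings the cytotoxicity into the readable range. The step from compound 3 to compound 4 is therefore expected to be a step that the limit leaves unreadable from compound 3 to compound 4, not discernible beyond the scatter. Compound 4 is estimated to give 45 ug/mL in this assay, within a range from 20 ug/mL to 120 ug/mL, most probably again reported as a limit.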

Compound 4, concentration for 50% growth inhibition: > 30 ug/mL
Compound 4 gave a limit, no number; the forecaster's own chance of this, stated with the estimate: 85%; the middle value does not contradict the limit.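

In this assay compound 4 gives > 30 ug/mL, which is a limit and not a number. No step from compound 1, compound 2 or compound 3 to compound 4 can be read, as all four compounds stand at the same point: the limit of > 30 ug/mL in this assay, at which 4 of the 4 values shown sit.

The compounds shown leave open whether any change on the phenyl ring alters growth inhibition in this assay.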